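The source may report more compounds than this note shows. Statements on the series, on what has been measured and on what is new or still open speak of the compounds shown alone.

Working notes on the series. Compound 1 `CC1CCN(c2c(S(=O)(=O)c3ccc(F)c(F)c3)cnc3cc(Cl)ccc23)CC1` and compound 2 `CC1CCN(c2c(S(=O)(=O)c3ccc(Cl)cc3)cnc3cc(F)ccc23)CC1` have both been measured in an assay on isolated protein for displacement of a labelled ligand from metabotropic glutamate receptor 5 (Homo sapiens), with a stated time of 60 min, tested at 1 uM; on this read-out lower numbers stand for less inhibition and higher numbers for more inhibition at the one concentration tested (going by the name of the read-out). In this assay compound 1 gives 90%, and compound 2 gives 90%. Compound 2 therefore stands level with compound 1 at the digits reported; the two values lie within the usual scatter of each other, so no ordering between them is claimed.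

The next compound, compound 3 `CC1CCN(c2c(S(=O)(=O)c3ccc(Cl)cc3)cnc3cc(Cl)ccc23)CC1`, has not been measured in this assay. It differs from compound 2 in one place: chloro in place of fluoro on an aromatic carbon.

Among the compounds with values here, with no measured pair that isolates this exchange, the expectation for the step rests only on the two values above, both of which sit high on the read-out. The step from compound 2 to compound 3 is expected to be small, no change at the digits printed from compound 2 to compound 3 (within the scatter), and not beyond the scatter in either direction. Compound 3 is estimated at 90%, with a range from 80% to 97%.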

Compound 3, a percentage reported as inhibition, at one concentration (the size of the read-out at that concentration, not a potency): 91%
Estimate against measurement, compound 3: 1 percentage points below, within the range that was stated.
By their numbers in this assay, from the lowest: compounds 1, 2 and 3 (each within the scatter of the next).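

In this assay chloro in place of fluoro on this aromatic carbon of the shared core gives a number 1 percentage points higher from compound 2 to compound 3 (within the scatter); the number in this assay therefore stays level with either halogen when 4-chlorophenyl is on the sulfonyl sulfur. The sulfonyl substituent gives the same picture with chloro on the core, where 4-chlorophenyl in place of 3,4-difluorophenyl gives a number 1 percentage points higher from compound 1 to compound 3 (within the scatter). Nothing available bears on the reason for either result.

All three values sit high on a read-out taken at a single concentration, so any differences in potency among these compounds remain unresolved. Also open, on these data alone, is whether the level holds when this aromatic carbon carries something other than a halogen, such as a methoxy group, an amine or a carboxylic acid.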